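The compounds below may be only part of what the source reports. "The series", "measured", "known", "first", "only" and "open" are said of these compounds alone.

Compound 1 `CCCCCN1CCN(c2nc(N)nc3sc(-c4ccc(F)cc4)nc23)CC1`: > 10000 nM
Compound 2 `Cc1cccc(N2CCN(c3nc(N)nc4sc(-c5ccc(F)cc5)nc34)CC2)c1`: > 10000 nM
Compound 3 `Nc1nc(N2CCN(C(=O)COc3ccc(Cl)cc3)CC2)c2nc(Cc3ccc(F)cc3)sc2n1`: 700 nM

Going by the values given here, in a functional assay on cells (Lymphocyte, Homo sapiens) (a lower number here means a stronger inhibitor, a higher number a weaker inhibitor), compound 3 gives 700 nM, the only real number among the three measured compounds. Compound 1 reaches only the assay limit, > 10000 nM. Compound 2 likewise reaches only the limit, > 10000 nM. Among the compounds with values here, the step that the two limits leave unreadable from compound 1 to compound 2 is therefore unreadable, and compounds 1 and 2 differ from compound 3 in more than one place, so no measured step bears directly on the change to compound 4 `Cc1ccc(-c2nc3c(N4CCN(C(=O)COc5ccc(Cl)cc5)CC4)nc(N)nc3s2)cc1`: 4-methylphenyl in place of 4-fluorobenzyl on an aromatic carbon. Without a readable comparison, no direction can be predicted with confidence, and the weight of the limit of > 10000 nM in this assay, at which 2 of the 3 values shown sit, leaves room for a loss. For compound 4 the estimated value in this assay is 2000 nM, in the range 400 nM to 10000 nM. This is expected to correspond to a step of a 2.9-fold higher number from compound 3 to compound 4 (0.46 log units; beyond the scatter).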

Compound 4, half-maximal inhibitory concentration: 350 nM
The estimate for compound 4 lay 5.7-fold (0.76 log units) above the measured number; measured number outside the range, below it.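

In this assay, 4-methylphenyl in place of 4-fluorobenzyl gives a 2.0-fold lower number from compound 3 to compound 4 (0.30 log units; within the scatter), so at this aromatic carbon the two groups cannot be told apart. Going by these compounds alone, this is the only readable comparison at this position, since the one earlier step, between compound 1 and compound 2, cannot be read. Nothing shown gives a reason why the two groups read alike. Going by these compounds, what an amine, a carboxylic acid or a longer chain would do on this carbon stays open. So does whether a ring is needed here at all.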